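The source may hold more compounds than are shown below. What is called first, only, known or untested is meant among the compounds shown, and "the series" means these compounds.

Working notes on the series. For the measured compounds named here, compound 3 `O=c1c(C2N=C(c3ccccc3)SS2)coc2cc(Cl)c(Cl)cc12` stands second highest of the three numbers so far in a functional assay on HEp-2 cells (Homo sapiens) for inhibition, read by sulforhodamine B assay, with a stated time of 48 h, tested at 100 uM (a lower number here means less inhibition of growth, a higher number more inhibition of growth at the concentration tested), giving 51%. Compound 1 `O=c1c(C(=S)Nc2ccccc2)coc2cc(Cl)ccc12` gives 41% in this assay, which lies within the scatter of the number for compound 3. Compound 2 `O=c1c(C2N=C(c3ccccc3)SS2)coc2ccc(Cl)cc12` gives 69%, beyond the scatter. Going by the values given here, the one measured step at this ring position is a number 18 percentage points lower from compound 2 to compound 3 (beyond the scatter). Compound 4 `O=c1c(C2N=C(c3ccccc3)SS2)coc2cc(Cl)c(F)cc12` differs from compound 3 by fluoro in place of chloro on an aromatic carbon. Among the compounds with values here, no measured step exchanges one halogen for another, so the step from compound 2 to compound 3 bears on it only loosely; a step of modest size at most, in either direction, is expected, most likely none beyond the scatter. Compound 4 is expected to give 55% in this assay, between 40% and 72%, an expected step of a number 4 percentage points higher from compound 3 to compound 4 (within the scatter).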

Compound 4, percent growth inhibition at one concentration: 52%
Compound 4: the middle estimate sits 3 percentage points above what was measured, and the stated range covers the measured number.
By their numbers in this assay, from the lowest: compounds 1, 3 and 4 (each within the scatter of the next, the first and the last beyond it); then compound 2.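

In this assay, fluoro in place of chloro on this aromatic carbon, ortho to a chloro group, gives a number 1 percentage points higher from compound 3 to compound 4 (within the scatter). The earlier step at this position, chloro in place of hydrogen, gave a number 18 percentage points lower from compound 2 to compound 3 (beyond the scatter), whereas this first exchange of one halogen for another stays within the scatter. No evidence at hand bears on this result. From the compounds shown here alone, what remains open is whether a non-halogen group here, such as an amine or a methoxy group, would stay within the scatter of compound 4. Bromo at this position is equally open.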